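This account rests on a few compounds, and the source may have more. Where it says the series, first, only, none or still open, it means among the compounds named here.

Compound 1 `COc1ccc2c(OCC[C@@H]3NC(=O)N(C)CCCC/C=C\[C@@H]4C[C@@]4(C(=O)NS(=O)(=O)N(C)C)NC3=O)cc(-c3nc(C(C)C)cs3)nc2c1Cl` is a large ring-shaped molecule in which a sulfonyl group carries a dimethylamino substituent. In an ADME assay on cells (Homo sapiens) for activation (a higher number here means that more compound is tolerated, a lower number that less compound is tolerated), compound 1 gives 47800 nM. Its companion, compound 2 `COc1ccc2c(OCC[C@@H]3NC(=O)N(C)CCCC/C=C\[C@@H]4C[C@@]4(C(=O)NS(=O)(=O)C4(C)CC4)NC3=O)cc(-c3nc(C(C)C)cs3)nc2c1C`, differs at several points at once and gives 31900 nM in this assay. Of the two numbers, that of compound 1 is the higher, but the gap to compound 2 falls within the usual scatter of this measurement, so the two are not really told apart.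

Compound 3 `COc1ccc2c(OCC[C@@H]3NC(=O)N(C)CCCC/C=C\[C@@H]4C[C@@]4(C(=O)NS(=O)(=O)N4CCC[C@H]4C#N)NC3=O)cc(-c3nc(C(C)C)cs3)nc2c1Cl` is compound 1 with one change: 2-cyanopyrrolidin-1-yl in place of dimethylamino on a sulfonyl sulfur. For the measured compounds named here, no measured pair in this set isolates such a change, so its effect is unknown from the data. Given that the two measured compounds sit so close together, the step in this assay from compound 1 to compound 3 is expected to be small, most likely no larger than the scatter, with no clear direction, and is estimated as a 1.2-fold lower number from compound 1 to compound 3 (0.08 log units; within the scatter). On that basis compound 3 is expected to give about 40000 nM, with a likely range from 15000 nM to 100000 nM.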

Compound 3, half-maximal cytotoxic concentration: 28300 nM
Compound 3: middle estimate off by 1.4-fold (0.15 log units), on the high side; the measured number falls inside the stated range.
By their numbers in this assay, from the lowest: compounds 3, 2 and 1 (each within the scatter of the next).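

Replacing dimethylamino with 2-cyanopyrrolidin-1-yl on a sulfonyl sulfur gives a 1.7-fold lower number from compound 1 to compound 3 (0.23 log units; within the scatter) in this assay and so shows that, in this one pair, a group of 7 heavy atoms with a ring and a nitrile can take the place of a group of 3 heavy atoms without a change that stands out from the scatter. For the compounds shown here, this is the first comparison here that isolates this position, since compound 1 and compound 2 differ at several points at once and could not show the effect of a single change at the sulfonyl sulfur. Nothing available explains the result or links it to any feature of the new group.

This single step leaves open whether the nitrile, the ring or the defined stereocentre matters, and plain pyrrolidin-1-yl or the opposite stereoisomer of the 2-cyanopyrrolidin-1-yl group would help to separate these features. Going by these compounds, it is also open whether the same result would hold for a group carrying a carboxylic acid, a primary amine or a longer alkyl chain at this position.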